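Adding a Dimethylamino Group to a Pyridine Amide

This account rests on a few compounds, and the source may have more. Where it says the series, first, only, none or still open, it means among the compounds named here.

Measured compounds:
compound 1, `O=C(c1ccc(Cl)cc1)N1CCC(NS(=O)(=O)c2cc(S(=O)(=O)c3ccccc3)ccc2C(F)(F)F)CC1`: 1800 nM
compound 2, `O=C(c1cccnc1)N1CCC(NS(=O)(=O)c2cc(S(=O)(=O)c3ccccc3)ccc2C(F)(F)F)CC1`: 120 nM

Going by the values given here, in an assay on U2OS cells for inhibition of secreted frizzled-related protein 1 (Homo sapiens), read by a luciferase reporter, with a stated time of 18 h (a lower number here means that less compound is needed, a higher number that more compound is needed for the effect), compound 2 gives 120 nM, the lowest of the two numbers recorded, and its only neighbour is compound 1, which gives 1800 nM. Among the compounds with values here, the one measured step, a 15-fold lower number from compound 1 to compound 2 (1.18 log units; beyond the scatter), comes from exchanging the whole aromatic group on the carbonyl carbon.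

Compound 3, `CN(C)c1ccc(C(=O)N2CCC(NS(=O)(=O)c3cc(S(=O)(=O)c4ccccc4)ccc3C(F)(F)F)CC2)cn1`, differs from compound 2 in one place: dimethylamino in place of hydrogen on an aromatic carbon. Within the data shown here, no measured step concerns adding a group onto this ring; the step from compound 1 to compound 2 swapped the ring itself rather than decorating it, so it offers no direct guide to the size or direction of the present change. With only the shared core and the same carbonyl-linked ring retained, the expected step is a 1.1-fold lower number from compound 2 to compound 3 (0.04 log units; within the scatter), that is, no change beyond the scatter. Compound 3 is therefore estimated at 110 nM, with a range from 35 nM to 400 nM.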

Compound 3, half-maximal effective concentration: 70 nM
Compound 3: middle estimate off by 1.6-fold (0.20 log units), on the high side; low and high end bracket the measured number.
By their numbers in this assay, from the lowest: compounds 3 and 2 (each within the scatter of the next); then compound 1.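

In this assay, dimethylamino on the aromatic carbon next to the ring nitrogen gives a 1.7-fold lower number from compound 2 to compound 3 (0.23 log units; within the scatter), so a group of this size can sit at this position of the pyridin-3-yl ring with no change that stands out from the scatter. The earlier step replaced one whole ring with another, whereas this one shows that the ring can also carry an added group, and a 26-fold lower number from compound 1 to compound 3 (1.41 log units; beyond the scatter) shows that the wide gap from the 4-chlorophenyl compound remains. Nothing available explains why the added group is accepted here.

Going by these compounds, whether a plain amino group, a methoxy group or a morpholin-4-yl ring would be accepted equally well at this position remains open. So does the effect of placing dimethylamino on a different carbon of the ring.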